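The source may report more compounds than this note shows. Statements on the series, on what has been measured and on what is new or still open speak of the compounds shown alone.

Compound 1 `COc1ccc(-c2ccc(-c3ccc(C(=N)N)o3)o2)cc1` and compound 2 `N=C(N)c1ccc(-c2ccc(-c3cncc4ccccc34)s2)s1` both carry an amidine at one end. In a functional assay on RXF 393 cells (Homo sapiens) for inhibition, read by sulforhodamine B assay, with a stated time of 48 h (on this read-out lower numbers stand for stronger inhibition of growth and higher numbers for weaker inhibition of growth), compound 1 gives 2120 nM and compound 2 gives 1600 nM; the gap between the two numbers lies within the scatter, so compound 1 does not stand apart from compound 2 on these data. Compound 3 `N=C(N)c1ccc(-c2ccc(-c3ccccc3)o2)o1` differs from compound 1 by hydrogen in place of methoxy on an aromatic carbon. Among the measured compounds shown here, no measured pair shows what hydrogen in place of methoxy on an aromatic carbon does in this assay, so the step of a 1.2-fold higher number from compound 1 to compound 3 (0.09 log units; within the scatter) is expected to stay within the scatter, leaning if anything toward weaker growth inhibition. Compound 3 is expected to give 2600 nM in this assay, between 1000 nM and 7000 nM.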

Compound 3, concentration for 50% growth inhibition: 2330 nM
The estimate for compound 3 lay 1.1-fold (0.05 log units) above the measured number; the measured number falls inside the stated range.
By their numbers in this assay, from the lowest: compounds 2, 1 and 3 (each within the scatter of the next).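

Hydrogen in place of methoxy, on an aromatic carbon para to a large group, gives a 1.1-fold higher number from compound 1 to compound 3 (0.04 log units; within the scatter) in this assay, the first direct reading of this change in the series. On the core of compound 1, growth inhibition at this level therefore does not depend on the methoxy. No measured evidence bears on why this step is so small. On these data alone, whether an amine, a carboxylic acid or a longer chain at this place would move the number beyond the scatter stays open.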